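Swapping Bromo for Methyl on the Shared Core

This account rests on a few compounds, and the source may have more. Where it says the series, first, only, none or still open, it means among the compounds named here.

Three measured compounds share one core and differ only in the group on a nitrogen on an aromatic ring. Compound 1 `COc1cc2ncnc(Nc3ccc(Br)cc3)c2cc1OCCCCC(=O)Nc1ccc(S(N)(=O)=O)cc1` gives 6570 nM in a functional assay on A-431 cells (Homo sapiens) for antiproliferative activity, read by MTT assay, with a stated time of 72 h (a lower number here means a stronger inhibitor, a higher number a weaker inhibitor), the lowest number of the three. Compound 2 `COc1ccc(Nc2ncnc3cc(OC)c(OCCCCC(=O)Nc4ccc(S(N)(=O)=O)cc4)cc23)cc1` gives 14700 nM, and compound 3 `COc1cc2ncnc(Nc3cc(F)c(F)c(F)c3)c2cc1OCCCCC(=O)Nc1ccc(S(N)(=O)=O)cc1` gives 23400 nM; the steps were a 2.2-fold higher number from compound 1 to compound 2 (0.35 log units; beyond the scatter) and a 3.6-fold higher number from compound 1 to compound 3 (0.55 log units; beyond the scatter), while a 1.6-fold higher number from compound 2 to compound 3 (0.20 log units; within the scatter). Compound 4 `COc1cc2ncnc(Nc3ccc(C)cc3)c2cc1OCCCCC(=O)Nc1ccc(S(N)(=O)=O)cc1` differs from compound 1 by methyl in place of bromo on an aromatic carbon. Both measured changes away from bromo gave modest rises in the number, so a step of similar or smaller size is expected here, upward or none beyond the scatter. Compound 4 is estimated at 9500 nM, between 4000 nM and 22000 nM, which means an expected step of a 1.4-fold higher number from compound 1 to compound 4 (0.16 log units; within the scatter).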

Compound 4, half-maximal inhibitory concentration: 35500 nM
For compound 4 the middle estimate is 3.7-fold (0.57 log units) below the measured one; the whole stated range lies below it.
By their numbers in this assay, from the lowest: compound 1; then compounds 2, 3 and 4 (each within the scatter of the next, the first and the last beyond it).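

In this assay even trading one heavy atom for one heavy atom at this position, with no ring, hydrogen-bond donor, hydrogen-bond acceptor or charge on either side, gives a 5.4-fold higher number from compound 1 to compound 4 (0.73 log units; beyond the scatter) and so a very small swap here is enough to move the number. Methoxy to methyl gives a 2.4-fold higher number from compound 2 to compound 4 (0.38 log units; beyond the scatter) while 3,4,5-trifluorophenyl to 4-methylphenyl gives a 1.5-fold higher number from compound 3 to compound 4 (0.18 log units; within the scatter) and neither step brings the number back toward that of compound 1. Among these four, only compound 1 stands clear of all the others.

As far as these compounds go, whether chloro, an amine or a carboxylic acid at this position would come closer to compound 1 stays open. Nothing given here explains why methyl and bromo differ.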